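Compound 1 at the solubility limit: swapping fluoro for nitro

A few compounds are considered here, and "the series" means these few. Any claim that something is new, unique, unknown or untested is made for them only; others in the source may bear on it.

In a physicochemical assay for solubility, in phosphate buffer, at pH 7.4 (a lower number here means a less soluble compound, a higher number a more soluble compound), compound 1 (`CCOC(=O)c1c(-c2cccc(F)c2)[nH]c2cccc(OC)c2c1=O`) gives > 100000 nM as its reading, which is a limit of the assay and not a number. Compound 2 (`CCOC(=O)c1c(-c2cccs2)[nH]c2cc(OC)ccc2c1=O`) gives > 100000 nM as its reading, again a limit. Together they show the limit of > 100000 nM in this assay, at which 2 of the 2 values shown sit, and so offer no measured step to learn from.

Compound 3 (`CCOC(=O)c1c(-c2cccc([N+](=O)[O-])c2)[nH]c2cccc(OC)c2c1=O`) keeps the core of compound 1 and carries nitro in place of fluoro on an aromatic carbon, the change from 3-fluorophenyl to 3-nitrophenyl. The difference reads nitro in place of fluoro on an aromatic carbon and lies on a six-membered aromatic ring of carbon only, meta to a large group.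

The expectation leans on compound 1 alone as the closest neighbour, with its limit of > 100000 nM as the only anchor. The expected step of an at least 1.1-fold lower number from compound 1 to compound 3 (0.04 log units; that floor lies within the scatter) in this assay is none beyond the scatter, with no firm direction. The reading for compound 3 may well come back as a limit again. Compound 3 is estimated at 90000 nM as a value, with an expected range from 30000 nM to 150000 nM in this measurement.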

Compound 3, solubility: 49000 nM
Beside the measured number, compound 3's estimate is 1.8-fold (0.26 log units) above it; the range from low to high includes it.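

In this assay compound 3 gives 49000 nM, the first reading among the compounds shown that is a number and not a limit, so this aromatic carbon now has one value that sits on the measurable scale. Compound 1 gives > 100000 nM, which is a limit of the assay and not a number. The swap of fluoro for nitro therefore reads as an at least 2.0-fold lower number from compound 1 to compound 3 (0.30 log units; that floor lies within the scatter), and only the floor of this step is known because one end of it is a limit: the limit of > 100000 nM in this assay, at which 2 of the 3 values shown sit.

Going by these compounds, whether an amine or a carboxylic acid on the same aromatic carbon would leave the reading at the assay limit or bring it into the measurable range remains open. Also open, on these data alone, is whether nitro in place of fluoro would lower the number in the same way on another core, as this change appears here in a single pair of compounds and the true size of its step cannot be read from that pair.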